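Replacing the phenyl of compound 3

The source may report more compounds than this note shows. Statements on the series, on what has been measured and on what is new or still open speak of the compounds shown alone.

In an ADME assay on a cell-free system (plasma, Homo sapiens) for metabolic stability (a lower number here means that the compound disappears faster, a higher number that the compound lasts longer), compound 1 (`CCCCN(CCCC)Cc1cccc(C(=O)OCCOCn2cnc3c(=O)[nH]c(N)nc32)c1`) gives 0.0383 h and compound 3 (`CS(=O)(=O)N(COC(=O)c1ccccc1)c1ccc([N+](=O)[O-])cc1Oc1ccccc1`) gives 0.0322 h, two values within the scatter of each other. Compound 2 (`CC(=O)OCOC(=O)N(C)/N=N/c1ccc(Br)cc1`) gives 0.283 h, beyond the scatter from both, so compound 3 sits with compound 1 at the short-lived end of this small set. Compound 4 (`CCOC(=O)CN(C)C(=O)OCN(c1ccc([N+](=O)[O-])cc1Oc1ccccc1)S(C)(=O)=O`) carries ((ethoxycarbonyl)methyl)(methyl)amino in place of phenyl on a carbonyl carbon. Going by the values given here, no measured pair shows this change, so the expectation is loose. Among the compounds with values here, it leans on compound 2 at 0.283 h, the only measured compound with an amino group on such a carbonyl carbon. The expected change is a 12-fold higher number from compound 3 to compound 4 (1.09 log units; beyond the scatter), an estimated rise beyond the scatter. The estimated half-life of compound 4 is 0.4 h, with an expected range of 0.08 h to 2.5 h.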

Compound 4, half-life: 49.2 h
Compound 4: middle estimate off by 120-fold (2.09 log units), on the low side, outside the stated range (above it).
By their numbers in this assay, from the lowest: compounds 3 and 1 (each within the scatter of the next); then compound 2; then compound 4.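

On the carbonyl carbon of this shared core, ((ethoxycarbonyl)methyl)(methyl)amino in place of phenyl changes the outcome dramatically: in this assay the change gives a 1500-fold higher number from compound 3 to compound 4 (3.18 log units; beyond the scatter). The same difference reads as benzoyloxy giving way to (((ethoxycarbonyl)methyl)(methyl)carbamoyl)oxy, so this position clearly has a large bearing on half-life. Nothing available explains the size of this step. The compounds shown leave open whether the rise belongs to the nitrogen on the carbonyl carbon or to the rest of the entering group. A dimethylamino or an ethoxy group at this place would bear on that question.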